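Removing a Methyl Group from a Low-Toxicity Series

This account rests on a few compounds, and the source may have more. Where it says the series, first, only, none or still open, it means among the compounds named here.

Of the compounds shown here, three built on one shared core have been tested so far. In an ADME assay on Vero cells (Chlorocebus sabaeus) for cytotoxicity, with a stated time of 72 h, tested at 50 ug/mL (on this read-out higher numbers stand for a stronger effect at the one concentration tested and lower numbers for a weaker effect), compound 1 `N=c1c(=O)[nH]nc2n1CCN2c1cccc(Cl)c1` gives 0%. Compound 2 `N=c1c(=O)[nH]nc2n1CCN2c1ccccc1Cl` gives 2% in this assay. Compound 3 `Cc1ccc(N2CCn3c2n[nH]c(=O)c3=N)cc1` gives 0% in this assay. Compound 3 thus stands level with compound 1 at the digits shown, and these two are together the lowest of the three numbers; compound 2 is the furthest from compound 3, yet its number lies within the usual scatter of this kind of measurement, so no real difference among the three can be claimed. All three compounds show essentially no effect at the single concentration tested.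

The next compound, compound 4 `N=c1c(=O)[nH]nc2n1CCN2c1ccccc1`, has not yet been measured in this assay. It differs from compound 3 in one place: hydrogen in place of methyl on an aromatic carbon. Going by the values given here, no pair of measured compounds differs in just one place, so there is no measured step to guide the expectation directly. Because compound 3 gives 0% and the other two measured compounds sit at the same low level, the step of a number 1 percentage points higher from compound 3 to compound 4 (within the scatter) is expected to be none beyond the scatter. Compound 4 is therefore estimated at 1%, within a range from 0% to 10%.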

Compound 4, a percentage reported as inhibition, at one concentration (the size of the read-out at that concentration, not a potency): 30%
Beside the measured number, compound 4's estimate is 29 percentage points below it, and the stated range ends below it.
By their numbers in this assay, from the lowest: compounds 1, 3 and 2 (each within the scatter of the next); then compound 4.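

Hydrogen in place of methyl on an aromatic carbon, para to a large group, gives a number 30 percentage points higher from compound 3 to compound 4 (beyond the scatter) in this assay, which shows that this small change at this position can matter, although the earlier compounds alone gave no sign of it. Hydrogen in place of chloro on an aromatic carbon points the same way, giving a number 28 percentage points higher from compound 2 to compound 4 (beyond the scatter) and also a number 30 percentage points higher from compound 1 to compound 4 (beyond the scatter), so within these four compounds a methyl or chloro on the six-membered aromatic ring goes with a low number, the unsubstituted ring goes with a clearly higher one, and no compound shown goes against this. No measurement shown here bears on the reason for the rise.

Still open, going by these compounds, is whether the low numbers depend on methyl and chloro in particular, or whether another group on this ring, such as a methoxy group, an amine or a carboxylic acid, would also keep the number low. With only one concentration tested, these numbers also leave open how the effect of compound 4 would change at other concentrations.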